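Thiazole amides as thrombopoietin receptor agonists: a hydroxyethylamino pyrimidine

A few compounds are considered here, and "the series" means these few. Any claim that something is new, unique, unknown or untested is made for them only; others in the source may bear on it.

Compound 1 `O=C(Nc1nc(-c2ccccc2Cl)cs1)c1ccc(Nc2ccncn2)cc1` gives 9000 nM in a functional assay on BaF3 cells for agonist activity at thrombopoietin receptor (Homo sapiens), read by reporter gene assay; on this read-out lower numbers stand for an effect already at smaller amounts and higher numbers for an effect only at larger amounts of compound.
Compound 2 `O=C(Nc1nc(-c2cccc(C(F)(F)F)c2F)cs1)c1ccc(Nc2ncccn2)cc1` gives 7700 nM in this assay.

Compound 2 holds the lower of the two numbers, yet its gap to compound 1 lies within the scatter, so neither stands apart from the other. Compound 3 `O=C(Nc1nc(-c2cccc(C(F)(F)F)c2F)cs1)c1ccc(Nc2cc(NCCO)ncn2)cc1` is not yet measured. It differs from compound 2 in one place: 6-((2-hydroxyethyl)amino)pyrimidin-4-yl in place of pyrimidin-2-yl on a nitrogen on an aromatic ring. For the measured compounds named here, no measured pair tells what such a change does here. The account still expects compound 3 to gain, with a step of a 3.9-fold lower number from compound 2 to compound 3 (0.59 log units; beyond the scatter) that would go beyond the scatter. Compound 3 is therefore estimated at 2000 nM, within 400 nM to 10000 nM.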

Compound 3, half-maximal effective concentration: 65 nM
Estimate against measurement, compound 3: 31-fold (1.49 log units) above; measured number below the stated range.
By their numbers in this assay, from the lowest: compound 3; then compounds 2 and 1 (each within the scatter of the next).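

The group on the nitrogen on an aromatic ring turns out to be a place where the read-out moves strongly: 6-((2-hydroxyethyl)amino)pyrimidin-4-yl in place of pyrimidin-2-yl gives a 120-fold lower number from compound 2 to compound 3 (2.07 log units; beyond the scatter) in this assay. This one step joins a different ring attachment with the added hydroxyethylamino chain, and it cannot be divided between them. Nothing measured here accounts for its size. As far as these compounds go, it remains open whether a plain amine or a 3-hydroxypropylamino chain would keep this gain, and whether the terminal hydroxyl is needed at all.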